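Imide nitrogen substituent in a sulfonamide aryl ether series

The source may report more compounds than this note shows. Statements on the series, on what has been measured and on what is new or still open speak of the compounds shown alone.

Measured so far:
- compound 1, `COc1cc2c(c(Oc3cccc(NS(=O)(=O)c4ccc(Cl)cc4)c3)n1)C(=O)N(C1CC1)C2=O`: 19 nM
- compound 2, `CCN1C(=O)c2cc(C)nc(Oc3cccc(NS(=O)(=O)c4ccc(Cl)cc4)c3)c2C1=O`: 11 nM

Both compounds were run in a functional assay on HEK293 cells for agonist activity at Glucose-dependent insulinotropic receptor (Homo sapiens), read by cAMP accumulation, with a stated time of 30 min; a higher number here means that more compound is needed for the effect, a lower number that less compound is needed. In this assay compound 1 gives 19 nM and compound 2 gives 11 nM. Compound 2 thus carries the lower of the two numbers, but the gap to compound 1 is within the usual scatter, so no order between the two can be read from these data. Going by the values given here, the two compounds differ in more than one place (the group on the pyridine ring and the group on the imide nitrogen), so no single step between measured compounds is available.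

Compound 3, `Cc1cc2c(c(Oc3cccc(NS(=O)(=O)c4ccc(Cl)cc4)c3)n1)C(=O)N(c1ccccc1)C2=O`, has not been measured. It differs from compound 2 in one place: phenyl in place of ethyl on an amide-type nitrogen in a ring. Among the compounds with values here, there is no measured precedent for an aromatic ring on this nitrogen; the only guide is that cyclopropyl in compound 1 and ethyl in compound 2 both give numbers in the same band. On that basis no step beyond the scatter is expected in this assay, with the direction open. Compound 3 is therefore estimated at 20 nM, with a range of 5 nM to 100 nM, which corresponds to an expected step of a 1.8-fold higher number from compound 2 to compound 3 (0.26 log units; within the scatter).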

Compound 3, half-maximal effective concentration: 299 nM
The estimate for compound 3 lay 15-fold (1.17 log units) below the measured number; the whole stated range lies below it.
By their numbers in this assay, from the lowest: compounds 2 and 1 (each within the scatter of the next); then compound 3.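

In this assay, going by these compounds alone, the amide-type nitrogen in a ring proves sensitive to its substituent: phenyl in place of ethyl gives a 27-fold higher number from compound 2 to compound 3 (1.43 log units; beyond the scatter), the first single-place step and one well beyond the scatter. Ethyl, with 2 heavy atoms and no ring, leaves, and phenyl, with 6 heavy atoms in one six-membered aromatic ring of carbon only, enters, while the counts of hydrogen-bond donors, hydrogen-bond acceptors and net charge stay the same on both sides of the step. No measurement at hand accounts for the step, so the data give its size and direction but no explanation.

As far as these compounds go, whether the step goes with the aromatic ring itself or with the larger size of the group remains open, and a cyclohexyl group or a longer chain such as butyl on this nitrogen would separate the two readings. Also open, from the compounds shown here alone, is whether a benzyl group, or a phenyl ring carrying an amine or a carboxylic acid, would behave like phenyl here, and whether the step holds on the core of compound 1 as it does on the core of compound 2.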